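Iodo in place of methyl on the aryl of compound 1

The compounds below may be only part of what the source reports. "The series", "measured", "known", "first", "only" and "open" are said of these compounds alone.

Measured so far:
compound 1 `COc1ccccc1Oc1c(N)nc(-c2cccc(C)c2)nc1Cl` — 13100 nM
compound 2 `COc1ccccc1Oc1c(N)nc(-c2ccc(C)cc2)nc1Cl` — 17400 nM
compound 3 `COc1cccc(-c2nc(N)c(Oc3ccccc3OC)c(Cl)n2)c1` — 23600 nM

The three compounds share one core and differ only in the aryl group attached to it. In a functional assay on B16 cells (Mus musculus) for cytotoxicity, read by CCK-8 assay, with a stated time of 24 h (on this read-out lower numbers stand for stronger inhibition and higher numbers for weaker inhibition), compound 1 stands at the lowest of the three numbers, yet each step away from it, a 1.3-fold higher number from compound 1 to compound 2 (0.12 log units; within the scatter) and a 1.8-fold higher number from compound 1 to compound 3 (0.26 log units; within the scatter), lies within the scatter, as does a 1.4-fold higher number from compound 2 to compound 3 (0.13 log units; within the scatter). Nothing in these three values separates one aryl group from another beyond repeat variation.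

Compound 4 `COc1ccccc1Oc1c(N)nc(-c2cccc(I)c2)nc1Cl` has not been measured. Relative to compound 1 the change is iodo in place of methyl on an aromatic carbon. For the measured compounds named here, no measured step involves iodo, so the only guidance is indirect: the change from compound 1 to compound 3, methoxy in place of methyl at the same place, gave a 1.8-fold higher number from compound 1 to compound 3 (0.26 log units; within the scatter), within the scatter, and the shift of the methyl around the ring from compound 1 to compound 2 gave a 1.3-fold higher number from compound 1 to compound 2 (0.12 log units; within the scatter). Small changes to this aryl group have so far not moved the number beyond the scatter, so the expected step of a 1.1-fold lower number from compound 1 to compound 4 (0.04 log units; within the scatter) is likewise within the scatter. For compound 4 the estimate is 12000 nM, with a range of 5000 nM to 30000 nM.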

Compound 4, half-maximal inhibitory concentration: 27600 nM
Beside the measured number, compound 4's estimate is 2.3-fold (0.36 log units) below it; measured number inside the range.
By their numbers in this assay, from the lowest: compounds 1, 2, 3 and 4 (each within the scatter of the next, the first and the last beyond it).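

In this assay, for the compounds shown here, iodo in place of methyl on an aromatic carbon, meta to a large group, gives a 2.1-fold higher number from compound 1 to compound 4 (0.32 log units; beyond the scatter) and so is the first single change to pass the scatter, though only modestly. The other two steps to the iodo compound, a 1.2-fold higher number from compound 3 to compound 4 (0.07 log units; within the scatter) and a 1.6-fold higher number from compound 2 to compound 4 (0.20 log units; within the scatter), stay within the scatter, so the series shows no clean break: compound 1 and compound 4 separate from each other, while compound 2 and compound 3 separate from neither. No measurement is available that bears on why this exchange shifts the number.

Going by these compounds, whether the shift is particular to iodo remains open, since fluoro, chloro or bromo at the same place would show whether the other halogens stay with the methyl of compound 1 or go with the iodo of compound 4. Also open, on these data alone, are an amine or a carboxylic acid at that place, and iodo carried in the place of the methyl of compound 2, which would show whether the step depends on where the group sits on the ring.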